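The compounds below may be only part of what the source reports. "The series", "measured", "known", "first", "only" and "open" are said of these compounds alone.

Measured values in a functional assay on HeLa cells (Homo sapiens) for inhibition, read by sulforhodamine B assay (on this read-out higher numbers stand for weaker inhibition and lower numbers for stronger inhibition), for the compounds so far:
- Compound 1 `O=C1C=C(Nc2ccccc2F)C(=O)c2c1nc1n2[C@H]2OC[C@@H](O)[C@H]2OC1` gives 5120 nM 
- Compound 2 `COc1ccc(NC2=CC(=O)c3nc4n(c3C2=O)[C@H]2OC[C@@H](O)[C@H]2OC4)cc1` gives 4780 nM 
- Compound 3 `CCOc1ccccc1NC1=CC(=O)c2nc3n(c2C1=O)[C@H]1OC[C@@H](O)[C@H]1OC3` gives 6040 nM 

All three share one core and differ only in the group on the amine nitrogen. Compound 3 cannot be separated from the other two on these numbers. The step is a 1.2-fold higher number from compound 1 to compound 3 (0.07 log units; within the scatter) on one side and a 1.3-fold higher number from compound 2 to compound 3 (0.10 log units; within the scatter) on the other, and the remaining pair shows a 1.1-fold lower number from compound 1 to compound 2 (0.03 log units; within the scatter) as its step.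

Compound 4 `O=C1C=C(Nc2ccc(I)cc2)C(=O)c2c1nc1n2[C@H]2OC[C@@H](O)[C@H]2OC1` has not yet been measured. It keeps the shared core and differs from compound 3 at that same nitrogen: 4-iodophenyl in place of 2-ethoxyphenyl on an amine nitrogen. For the measured compounds named here, no measured compound carries iodine, so this exact swap is untested. Going by the values given here, the only guidance comes from the earlier swaps on that nitrogen, and even the largest of them, a 1.3-fold higher number from compound 2 to compound 3 (0.10 log units; within the scatter) as measured, stayed small. A step beyond the scatter is therefore not expected in this assay, although the new group keeps the range wide. The expected step is a 1.3-fold lower number from compound 3 to compound 4 (0.13 log units; within the scatter) according to this estimate. Compound 4 is estimated at 4500 nM with an expected range from 1800 nM to 10000 nM around that figure.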

Compound 4, half-maximal inhibitory concentration: 4070 nM
Compound 4: middle estimate off by 1.1-fold (0.04 log units), on the high side; the range from low to high includes it.
By their numbers in this assay, from the lowest: compounds 4, 2, 1 and 3 (each within the scatter of the next).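

In this assay the change to 4-iodophenyl on the amine nitrogen gives a 1.5-fold lower number from compound 3 to compound 4 (0.17 log units; within the scatter) and so, although it is the largest step among these four compounds, it does not separate the pair. The comparisons with the other two compounds read the same way, with a 1.2-fold lower number from compound 2 to compound 4 (0.07 log units; within the scatter) and a 1.3-fold lower number from compound 1 to compound 4 (0.10 log units; within the scatter) as their steps. Iodine is new at this position, and the result extends what fluoro, methoxy and ethoxy had shown: across these four aryl groups on the nitrogen, every step stays within the scatter, so this read-out does not rank them.

No measurement shown here offers an explanation for why these swaps leave the numbers so close. From the compounds shown here alone, what stays open is whether a group of another kind on this nitrogen would produce a step beyond the scatter, for example a phenyl ring carrying a carboxylic acid or an amine, or a longer alkyl chain in place of the phenyl ring.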